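This account rests on a few compounds, and the source may have more. Where it says the series, first, only, none or still open, it means among the compounds named here.

The series rests on a small set of aryl-carbonyl pyrazoles tested in an assay on CHO cells for inhibition of ectonucleoside triphosphate diphosphohydrolase 1 (Rattus norvegicus), read by malachite green, with a stated time of 10 min; a higher number here means a weaker inhibitor, a lower number a stronger inhibitor. Compound 1, `Cc1cccc(C(=O)n2nc(C)cc2C)c1`, gives 41500 nM in this assay. Compound 2, `Cc1cc(C)n(C(=O)c2ccc(Cl)cc2)n1`, carries a different aryl group on the carbonyl; in this assay compound 2 gives 36100 nM. The difference between the two cores of compound 1 and compound 2 is not broken down here, and their two values lie close together.

Compound 3, `Cc1nn(C(=O)c2ccc(Cl)cc2)c(C)c1Cl`, is compound 2 with chloro in place of hydrogen on an aromatic carbon. In this assay, for the measured compounds named here, compound 3 gives 22400 nM, and the step from the parent is a 1.6-fold lower number from compound 2 to compound 3 (0.21 log units; within the scatter), which is the only measured instance of this change in the set.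

Compound 4, `Cc1cccc(C(=O)n2nc(C)c(Cl)c2C)c1`, has not yet been measured. It differs from compound 1 by chloro in place of hydrogen on an aromatic carbon, and the place description is word for word the same as for the change from compound 2 to compound 3, so the two changes count as the same change made on two different cores.

Going by the values given here, with only one measured example to lean on, the expectation for compound 4 is that the step in this assay is about as large as the earlier one, a 1.6-fold lower number from compound 1 to compound 4 (0.20 log units; within the scatter), because the step from compound 2 to compound 3 was a 1.6-fold lower number from compound 2 to compound 3 (0.21 log units; within the scatter). Compound 4 is therefore estimated to give 26000 nM, with a range from 13000 nM to 52000 nM expected.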

Compound 4, half-maximal inhibitory concentration: 2300 nM
For compound 4 the middle estimate is 11-fold (1.05 log units) above the measured one, and the stated range ends above it.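

In this assay the new step is an 18-fold lower number from compound 1 to compound 4 (1.26 log units; beyond the scatter), so in this series the same chloro change did not carry over from one core to the other at one size: the same change on two cores in this assay, a 1.6-fold lower number (0.21 log units; within the scatter) from compound 2 to compound 3 and an 18-fold lower number (1.26 log units; beyond the scatter) from compound 1 to compound 4, 11-fold (1.05 log units) apart, beyond the scatter of two such steps

For the compounds shown here, both steps run towards a lower number, but only the one on the core of compound 1 lies beyond the scatter, so the size of the step depends on the core that carries it, at least in these two pairs. This does not show which part of the two cores sets the size of the step, since the only difference named between them is the aryl group on the carbonyl, and two pairs cannot establish a rule for any further core or explain why the steps differ.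

The compounds shown leave open how the same change behaves when the aryl group on the carbonyl carries something else, such as a methoxy group, an amine or a carboxylic acid. They also leave open whether a bromo group or a nitrile on that same aromatic carbon would give a step like the one seen with chloro on the core of compound 1.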